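The source may report more compounds than this note shows. Statements on the series, on what has been measured and on what is new or still open speak of the compounds shown alone.

Measured compounds in a functional assay on HT-29 cells (Homo sapiens) for inhibition, read by luminescence and CellTiter-Glo, with a stated time of 24 h; a lower number here means that less compound is needed, a higher number that more compound is needed for the effect:
- compound 1, `COCCn1nc(C(=O)N[C@H]2COc3ccccc3N(C)C2=S)nc1Cc1ccccc1`, gives 566 nM
- compound 2, `CN1C(=S)[C@@H](NC(=O)c2nc(Cc3ccccc3)n(C3CCCC3)n2)COc2ccccc21`, gives 3530 nM
- compound 3, `CN1C(=S)[C@@H](NC(=O)c2nc(Cc3ccccc3)n(CC3CCOCC3)n2)COc2ccccc21`, gives 6310 nM

Compound 1 has the lowest number of the three, so it needs the least compound for the effect; the steps from it to both others lie beyond the scatter. The two other compounds sit within the scatter of each other, as the step of a 1.8-fold higher number from compound 2 to compound 3 (0.25 log units; within the scatter) shows.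

Compound 4, `CN1C(=S)[C@@H](NC(=O)c2nc(Cc3ccccc3)n(C3CCNCC3)n2)COc2ccccc21`, has not yet been measured. It differs from compound 1 in one place: piperidin-4-yl in place of 2-methoxyethyl on an aromatic nitrogen.

Going by the values given here, two measured steps bear on this change, both replacing the 2-methoxyethyl group of compound 1 on the same aromatic nitrogen: a 6.2-fold higher number from compound 1 to compound 2 (0.79 log units; beyond the scatter), and an 11-fold higher number from compound 1 to compound 3 (1.05 log units; beyond the scatter). The change to compound 4 again swaps the 2-methoxyethyl group for a ring, here one carrying a hydrogen-bond donor, so a higher number in this assay is expected, of a size like these two steps, roughly a 5.3-fold higher number from compound 1 to compound 4 (0.72 log units; beyond the scatter).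

Compound 4 is therefore estimated at 3000 nM, with a range of 800 nM to 12000 nM.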

Compound 4, half-maximal effective concentration: 1000 nM
Compound 4: the middle estimate sits 3.0-fold (0.48 log units) above what was measured; low and high end bracket the measured number.
By their numbers in this assay, from the lowest: compounds 1 and 4 (each within the scatter of the next); then compounds 2 and 3 (each within the scatter of the next).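

In this assay, piperidin-4-yl on the aromatic nitrogen stays within the scatter of the 2-methoxyethyl group of compound 1 (a 1.8-fold higher number from compound 1 to compound 4 (0.25 log units; within the scatter)), so a six-membered ring at this position is compatible with a number in the range of compound 1. The ring itself does not settle the outcome, since the other two ring-bearing groups, cyclopentyl and (oxan-4-yl)methyl, both stand apart from piperidin-4-yl (a 3.5-fold lower number from compound 2 to compound 4 (0.55 log units; beyond the scatter); a 6.3-fold lower number from compound 3 to compound 4 (0.80 log units; beyond the scatter)). Nothing measured here explains why piperidin-4-yl differs from these groups.

Going by these compounds, it remains open whether the ring nitrogen and its hydrogen matter, or the ring's shape and its direct attachment to the aromatic nitrogen. A 1-methylpiperidin-4-yl group or a 2-aminoethyl chain at the same place would help separate these possibilities.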